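The compounds below may be only part of what the source reports. "The series", "measured", "known", "first", "only" and "open" are said of these compounds alone.

Compound 1 `O=C(NCc1cn(Cc2ccc(Cl)cc2)nn1)c1cn(-c2ccccc2)nc1-c1ccc(F)cc1`, compound 2 `COc1ccc(Cn2cc(CNC(=O)c3cn(-c4ccccc4)nc3-c3ccc(F)cc3)nn2)cc1` and compound 3 `COc1cc(Cn2cc(CNC(=O)c3cn(-c4ccccc4)nc3-c3ccc(F)cc3)nn2)cc(OC)c1`. In a functional assay on MCF7 cells (Homo sapiens) for antiproliferative activity, read by sulforhodamine B assay, with a stated time of 48 h (on this read-out higher numbers stand for weaker inhibition of growth and lower numbers for stronger inhibition of growth), compound 1 gives 130 nM, compound 2 gives 650 nM and compound 3 gives 2500 nM.

Compound 1 has the lowest number of the three measured compounds. Compound 4 `COc1ccc(-c2nn(-c3ccccc3)cc2C(=O)NCc2cn(Cc3ccc(Cl)cc3)nn2)cc1` differs from it by methoxy in place of fluoro on an aromatic carbon. Within the data shown here, none of the measured steps changes this ring; the nearest guide is a 5.0-fold higher number from compound 1 to compound 2 (0.70 log units; beyond the scatter), which also puts a methoxy in place of a halogen, though on a different ring, with a 19-fold higher number from compound 1 to compound 3 (1.28 log units; beyond the scatter) and a 3.8-fold higher number from compound 2 to compound 3 (0.59 log units; beyond the scatter) on that same other ring. Taken loosely, a modest rise in the number is expected for compound 4 in this assay, about a 2.7-fold higher number from compound 1 to compound 4 (0.43 log units; beyond the scatter). Compound 4 is therefore estimated at 350 nM, with a range from 120 nM to 1000 nM.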

Compound 4, concentration for 50% growth inhibition: 2900 nM
Compound 4: the middle estimate sits 8.3-fold (0.92 log units) below what was measured, outside the stated range (above it).
By their numbers in this assay, from the lowest: compound 1; then compound 2; then compounds 3 and 4 (each within the scatter of the next).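

In this assay, methoxy in place of fluoro on this ring gives a 22-fold higher number from compound 1 to compound 4 (1.35 log units; beyond the scatter) and so turns a single small exchange into a large step. The earlier compounds shown here showed sensitivity only on the other aromatic ring, as in a 5.0-fold higher number from compound 1 to compound 2 (0.70 log units; beyond the scatter) and a 19-fold higher number from compound 1 to compound 3 (1.28 log units; beyond the scatter) and the outcome here shows that the 4-fluorophenyl position is at least as demanding of the group it carries. Nothing available accounts for this rise.

As far as these compounds go, what an amine or a hydroxyl would do at this position remains open. From the compounds shown here alone, it also remains open whether the step belongs to methoxy specifically or to any replacement of fluoro.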